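The source may report more compounds than this note shows. Statements on the series, on what has been measured and on what is new or still open speak of the compounds shown alone.

Measured so far in a functional assay on the whole organism (strain Wistar) for inhibition, with Rattus norvegicus as the target, read by paw edema, with stated times of 60 min and 3 h, at a dose of 100 mg/kg by the oral route; a lower number here means less inhibition, a higher number more inhibition at the dose given (going by the name of the read-out):

compound 1, `CCN(CC)C(=O)CC1CCc2cc(OC)c(OC)cc21`, gives 37.7%
compound 2, `CCCNC(=O)CC1CCc2cc(OC)c(OC)cc21`, gives 29%
compound 3, `CCCCCNC(=O)CC1CCc2cc(OC)c(OC)cc21`, gives 37.7%

All three share one core and differ only in the group on the amide carbonyl. Compound 3 and compound 1 give the same figure, no change at the digits printed from compound 1 to compound 3 (within the scatter), and compound 2 lies close to both: a number 8.7 percentage points lower from compound 1 to compound 2 (within the scatter) and a number 8.7 percentage points higher from compound 2 to compound 3 (within the scatter). None of these three amide changes moves the read-out beyond the scatter of this assay.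

Compound 4, `COc1cc2c(cc1OC)C(CC(=O)N1CCNCC1)CC2`, is the next step from compound 3: piperazin-1-yl in place of pentylamino on a carbonyl carbon. The change again sits on the carbonyl carbon, the same place where the three measured steps were made, and those steps all stayed within the scatter. A cyclic group bearing a second nitrogen has not been tried here, so the expectation rests only on those small steps. On that basis compound 4 is expected to give 35%, most likely between 20% and 50%, meaning an expected step of a number 2.7 percentage points lower from compound 3 to compound 4 (within the scatter).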

Compound 4, a percentage reported as inhibition, in the whole organism at one dose (the size of the read-out at that dose, not a potency): 42%
Compound 4: the middle estimate sits 7 percentage points below what was measured; the range from low to high includes it.
By their numbers in this assay, from the lowest: compounds 2, 1, 3 and 4 (each within the scatter of the next, the first and the last beyond it).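

In this assay, going by these compounds alone, piperazin-1-yl on the carbonyl carbon gives the first step at this position that passes the scatter, with a number 13 percentage points higher from compound 2 to compound 4 (beyond the scatter) when it replaces propylamino. That gain holds only against compound 2, as the same ring does not stand apart from the other two amides, with a number 4.3 percentage points higher from compound 3 to compound 4 (within the scatter) and a number 4.3 percentage points higher from compound 1 to compound 4 (within the scatter) for the replacements of pentylamino and diethylamino. So a six-membered ring with a second nitrogen is accepted on this carbonyl carbon, but no evidence here explains its separation from compound 2.

The compounds shown leave open whether the ring itself or its second nitrogen goes with this result. A piperidine or morpholine ring on the same carbonyl carbon would help separate the two, and a methylpiperazinyl group would probe that second nitrogen.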